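A few compounds are considered here, and "the series" means these few. Any claim that something is new, unique, unknown or untested is made for them only; others in the source may bear on it.

Measured compounds in an assay on cells for inhibition of HSP60/HSP10 (Homo sapiens), with a stated time of 60 min; a lower number here means a stronger inhibitor, a higher number a weaker inhibitor:
Compound 1 `COc1ccc(Cl)cc1S(=O)(=O)Nc1ccc(-c2nc3ccccc3o2)cc1` gives > 100000 nM, a limit of this assay and not a number.
Compound 2 `O=S(=O)(Nc1ccc2oc(-c3ccccc3)nc2c1)c1ccccc1Cl` gives > 100000 nM, likewise a limit.
Compound 3 `O=S(=O)(Nc1ccc2oc(-c3ccccc3)nc2c1)c1ccc(O)cc1` gives 88000 nM.

Compound 1 stands at the limit of > 100000 nM in this assay, at which 2 of the 3 values shown sit, so for it only a limit is known, and nothing more than that follows from its entry. Compound 4 `O=S(=O)(Nc1ccc(-c2nc3ccccc3o2)cc1)c1cccc(O)c1` differs from compound 1 in one place: 3-hydroxyphenyl in place of 5-chloro-2-methoxyphenyl on a sulfonyl sulfur.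

Among the compounds with values here, the only measured step that bears on this change is an at least 1.1-fold lower number from compound 2 to compound 3 (0.05 log units; that floor lies within the scatter), where a hydroxyphenyl group likewise replaces a chlorine-bearing phenyl group on the sulfonyl sulfur. That step moved from a limit to a number, but its floor sits within the scatter, so the gain it shows is small. The change from compound 1 to compound 4 is of the same kind, though on a different core and with the hydroxyl at a different position of the ring, and with the methoxy group also leaving.

No step beyond the scatter is therefore expected; compound 4 is estimated to sit near the limit again, with the step of a number no higher from compound 1 to compound 4 (the limit leaves the size open) expected to be small. The estimate for compound 4 is 100000 nM, with a range from 40000 nM to 300000 nM.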

Compound 4, half-maximal inhibitory concentration: 62000 nM
For compound 4 the middle estimate is 1.6-fold (0.21 log units) above the measured one; the range from low to high includes it.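

In this assay, 3-hydroxyphenyl in place of 5-chloro-2-methoxyphenyl on a sulfonyl sulfur gives an at least 1.6-fold lower number from compound 1 to compound 4 (0.20 log units; that floor lies within the scatter), so this position on the core of compound 1 can yield a measurable number. With an at least 1.1-fold lower number from compound 2 to compound 3 (0.05 log units; that floor lies within the scatter), there are now two pairs, on different cores, in which a hydroxyphenyl group replacing a chlorine-bearing phenyl group leads from a limit to a number, though both floors lie within the scatter. Compound 1 has only a limit, so the true size of its step stays open: the limit of > 100000 nM in this assay, at which 2 of the 4 values shown sit.

The step removes the chlorine and the methoxy group and adds the hydroxyl all at once, so the compounds shown do not separate these three changes. From the compounds shown here alone, how a 3-aminophenyl or 3-carboxyphenyl group on the sulfonyl sulfur would read in this assay also remains open.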